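Sulfonyl chain variation on the shared core

The source may report more compounds than this note shows. Statements on the series, on what has been measured and on what is new or still open speak of the compounds shown alone.

Of the compounds shown here, three of the shared core have been measured in a functional assay on CHO-K1 cells for agonist activity at Glucose-dependent insulinotropic receptor (Homo sapiens), read by a luciferase reporter, with a stated time of 5 h; a lower number here means that less compound is needed, a higher number that more compound is needed for the effect. Compound 1 `CC(C)OC(=O)N1CCC(COc2ccc(N3CCN(C(=O)c4ccco4)CC3)nc2)CC1` gives 1900 nM. Compound 2 `CCS(=O)(=O)N1CCN(c2ccc(OCC3CCN(C(=O)OC(C)C)CC3)cn2)CC1` gives 1300 nM. Compound 3 `CC(C)OC(=O)N1CCC(COc2ccc(N3CCN(S(=O)(=O)C(C)C)CC3)nc2)CC1` gives 300 nM, the lowest number of the three, with compound 2 nearest and compound 1 furthest. The steps read: a 1.5-fold lower number from compound 1 to compound 2 (0.16 log units; within the scatter) and a 6.3-fold lower number from compound 1 to compound 3 (0.80 log units; beyond the scatter).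

Compound 4 `COCCS(=O)(=O)N1CCN(c2ccc(OCC3CCN(C(=O)OC(C)C)CC3)cn2)CC1` has not yet been measured. It differs from compound 3 in that (2-methoxyethyl in place of isopropyl on a sulfonyl sulfur). Among the measured compounds shown here, no measured pair covers this exact exchange. The step that bears on it is a 4.3-fold lower number from compound 2 to compound 3 (0.64 log units; beyond the scatter), which separates a branched sulfonyl chain from a straight one. For the measured compounds named here, compound 4 carries a straight chain again, now lengthened by the 2-methoxyethyl group, so a modest move back toward the number of compound 2 is expected rather than a further fall, though the added chain length has no measured precedent. Compound 4 is therefore expected to give 700 nM in this assay, within 250 nM to 2000 nM. The expected step is a 2.3-fold higher number from compound 3 to compound 4 (0.37 log units; beyond the scatter).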

Compound 4, half-maximal effective concentration: 300 nM
For compound 4 the middle estimate is 2.3-fold (0.37 log units) above the measured one; the range from low to high includes it.
By their numbers in this assay, from the lowest: compounds 3 and 4 (each within the scatter of the next); then compounds 2 and 1 (each within the scatter of the next).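

In this assay a branched chain on the sulfonyl sulfur proves not to be required: 2-methoxyethyl in place of isopropyl gives no change at the digits printed from compound 3 to compound 4 (within the scatter) and so holds the level of the isopropyl compound. Methoxy on the ethyl chain gives a 4.3-fold lower number from compound 2 to compound 4 (0.64 log units; beyond the scatter) and the exchange for the (furan-2-yl)carbonyl group gives a 6.3-fold lower number from compound 1 to compound 4 (0.80 log units; beyond the scatter) as well, though compound 2 shows that not every unbranched sulfonyl chain reaches this level. Nothing measured here explains why the isopropyl and 2-methoxyethyl chains read alike.

The compounds shown leave open whether the step from the ethyl chain follows the ether oxygen or the added chain length, which a propyl or butyl chain on the sulfonyl sulfur would separate. From the compounds shown here alone, how a terminal amine or carboxylic acid on this chain would read also remains open.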